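Fluorophenyl to bromophenyl on a shared chalcone core

This account rests on a few compounds, and the source may have more. Where it says the series, first, only, none or still open, it means among the compounds named here.

Compound 1 `COc1ccc(/C=C/C(=O)c2ccc(OC)c3c2OC(C)(C)C=C3)c(F)c1` and compound 2 `COc1ccc(C(=O)/C=C/c2cccc(F)c2)c2c1C=CC(C)(C)O2` are the two measured compounds. In a functional assay on HCT-116 cells (Homo sapiens) for antiproliferative activity, read by MTT assay, with a stated time of 24 h (a lower number here means a stronger inhibitor, a higher number a weaker inhibitor), compound 1 gives only an assay limit, > 10000 nM. In this assay compound 2 likewise gives only a limit, > 10000 nM. Among the measured compounds shown here, the step that the two limits leave unreadable from compound 1 to compound 2 therefore cannot be sized, and the sole evidence is the limit of > 10000 nM in this assay, at which 2 of the 2 values shown sit. Compound 3 `COc1ccc(C(=O)/C=C/c2ccc(Br)cc2)c2c1C=CC(C)(C)O2` differs from compound 2 by 4-bromophenyl in place of 3-fluorophenyl on a double-bonded chain carbon bound to a double-bonded chain carbon. For the measured compounds named here, no measured step bears on this change, so the expected step of a number no higher from compound 2 to compound 3 (the limit leaves the size open) rests on no measured trend. Compound 3 is estimated at 10000 nM, between 3000 nM and 30000 nM, with a limit again likely.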

Compound 3, half-maximal inhibitory concentration: > 10000 nM
Compound 3 gave a limit, no number; the forecaster's own chance of this, stated with the estimate: 70%; the middle value sits exactly at the limit.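

No step among compound 1, compound 2 and compound 3 can be read, since each gives only a limit in this assay: the limit of > 10000 nM in this assay, at which 3 of the 3 values shown sit.

The compounds shown leave open how the fluorophenyl and bromophenyl groups compare on the shared core, and what would give a readable number.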